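The compounds below may be only part of what the source reports. "The series", "measured", "known", "first", "only" and "open" are said of these compounds alone.

Compound 2 `CCN1CCN(CC(=O)Nc2ccc(-c3nc(-c4ccccc4)c(-c4ccccc4)n3C)cc2)CC1` stands lowest of the two numbers measured in a functional assay on HT-29 cells (Homo sapiens) for cytotoxicity, read by MTT assay, with a stated time of 24 h, tested at 1.6 ug/mL; on this read-out lower numbers stand for a weaker effect and higher numbers for a stronger effect at the one concentration tested: in that assay compound 2 gives 13.9%. Its nearest neighbour is compound 1 `Cc1nnc(SCC(=O)Nc2ccc(-c3nc(-c4ccccc4)c(-c4ccccc4)n3C)cc2)s1`, and in this assay compound 1 gives 39.9%. Among the compounds with values here, the only measured step is a number 26 percentage points lower from compound 1 to compound 2 (beyond the scatter), a change at a saturated chain carbon bound to a carbonyl carbon. Compound 3 `COc1ccc(CN2CCN(CC(=O)Nc3ccc(-c4nc(-c5ccccc5)c(-c5ccccc5)n4C)cc3)CC2)cc1` differs from compound 2 at another place: 4-methoxyphenyl in place of methyl on a saturated chain carbon bound to an amine nitrogen in a ring. Within the data shown here, no measured step touches this place or this kind of change, so nothing among the two measured compounds speaks directly for a large move in this assay, and the one known step concerns a different part of the molecule. The expected step is therefore a number 8.1 percentage points higher from compound 2 to compound 3 (within the scatter), a move that is not expected to stand clearly beyond the scatter. Compound 3 is accordingly expected to give 22% in this assay, within a range from 8% to 45%.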

Compound 3, a percentage reported as activity, at one concentration (the size of the read-out at that concentration, not a potency): 10.1%
For compound 3 the middle estimate is 11.9 percentage points above the measured one; measured number inside the range.
By their numbers in this assay, from the lowest: compounds 3 and 2 (each within the scatter of the next); then compound 1.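

Putting 4-methoxyphenyl in place of methyl on a saturated chain carbon bound to an amine nitrogen in a ring gives, in this assay, a number 3.8 percentage points lower from compound 2 to compound 3 (within the scatter). The earlier step concerned only the saturated chain carbon bound to a carbonyl carbon, whereas this one shows that a group of 8 heavy atoms with a six-membered aromatic ring can enter at this new place without the read-out standing apart from that of the methyl it replaces. Nothing given here offers an explanation for this result.

As far as these compounds go, whether a plain phenyl, a pyridine ring or a carboxylic acid at this place would also read alike remains open. So does whether a longer chain between the amine nitrogen and the 4-methoxyphenyl would change the number at the one concentration tested.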